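Phenyl for Pyridin-2-yl on the Shared Core

The source may hold more compounds than are shown below. What is called first, only, known or untested is meant among the compounds shown, and "the series" means these compounds.

Three compounds have so far been measured in a functional assay on T47D cells (Homo sapiens) for cytotoxicity, read by CCK-8 assay and cell counting, with a stated time of 2 days; on this read-out higher numbers stand for weaker inhibition and lower numbers for stronger inhibition:

compound 1, `Oc1cccc(-c2cc(-c3ccc(Cl)cc3)nc(-c3cccnc3)c2)c1`, 18100 nM
compound 2, `Oc1cccc(-c2cc(-c3ccc(Cl)cc3)nc(-c3ccsc3)c2)c1`, 11500 nM
compound 3, `Oc1cccc(-c2cc(-c3ccc(Cl)cc3)nc(-c3ccccn3)c2)c1`, 13900 nM

Compound 3 stands close to both of its neighbours: a 1.3-fold lower number from compound 1 to compound 3 (0.11 log units; within the scatter) and a 1.2-fold higher number from compound 2 to compound 3 (0.08 log units; within the scatter), so none of the three can be ranked against the others. The remaining pair is no different, as a 1.6-fold lower number from compound 1 to compound 2 (0.20 log units; within the scatter) shows.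

Compound 4, `Oc1cccc(-c2cc(-c3ccccc3)nc(-c3ccc(Cl)cc3)c2)c1`, is yet to be measured. It differs from compound 3 in one place: phenyl in place of pyridin-2-yl on an aromatic carbon. Among the compounds with values here, no measured step removes a ring nitrogen altogether, so the steps that bear on it are those among compounds 1, 2 and 3, in which pyridin-3-yl, thiophen-3-yl and pyridin-2-yl occupy the same place on the shared core and give numbers that lie within the scatter of one another. On that record the group at this place has not moved this assay beyond the scatter, and no step beyond it is expected from compound 3 to compound 4 either. Compound 4 is therefore expected to give about 12000 nM in this assay, within a range of 5000 nM to 30000 nM, which would amount to an expected 1.2-fold lower number from compound 3 to compound 4 (0.06 log units; within the scatter).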

Compound 4, half-maximal inhibitory concentration: 11300 nM
Compound 4: the middle estimate sits 1.1-fold (0.03 log units) above what was measured, and the stated range covers the measured number.
By their numbers in this assay, from the lowest: compounds 4, 2, 3 and 1 (each within the scatter of the next).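

Replacing pyridin-2-yl with phenyl takes away the ring nitrogen and the hydrogen-bond acceptor counted for the group at this place, and in this assay this gives a 1.2-fold lower number from compound 3 to compound 4 (0.09 log units; within the scatter), so a six-membered aromatic ring of carbon only reads no differently here from one with a hetero atom. Set against the other two groups, phenyl gives a 1.0-fold lower number from compound 2 to compound 4 (0.01 log units; within the scatter) and a 1.6-fold lower number from compound 1 to compound 4 (0.20 log units; within the scatter), which means that across all four compounds neither the presence nor the position of a ring nitrogen in this group produces a step beyond the scatter. Nothing at hand accounts for why the numbers stay together at this place.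

Going by these compounds, all four groups at this place are unsubstituted aromatic rings, so it remains open whether an amine, a carboxylic acid or a longer alkyl chain there would move the number beyond the scatter. On these data alone, it is equally open whether a methoxy group or a fluorine atom carried on the phenyl ring of compound 4 would do so.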